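This account rests on a few compounds, and the source may have more. Where it says the series, first, only, none or still open, it means among the compounds named here.

In an ADME assay on HEK293 cells (Homo sapiens) for cytotoxicity, read by sulforhodamine B assay, with a stated time of 48 h, tested at 10 uM (a lower number here means less inhibition, a higher number more inhibition at the concentration tested (going by the name of the read-out)), the three measured compounds stand as follows:

Compound 1 `CCCCc1cn(C(c2ccccc2)c2cc3cc(Br)ccc3nc2OC)nn1` gives -3.47%.
Compound 2 `COc1nc2ccc(Br)cc2cc1C(c1ccccc1)n1cc(-c2ccc(Br)cc2)nn1` gives 6.28%.
Compound 3 `COc1nc2ccc(Br)cc2cc1C(c1ccccc1)n1cc(CO)nn1` gives 11.5%.

Compound 1 has the lowest of the three numbers; compound 2 is nearest, a number 9.8 percentage points higher from compound 1 to compound 2 (within the scatter), and compound 3 furthest, a number 15 percentage points higher from compound 1 to compound 3 (beyond the scatter). Compound 4 `COc1nc2ccc(Br)cc2cc1C(c1ccccc1)n1cc(CCO)nn1` differs from compound 1 by hydroxy in place of ethyl on a saturated chain carbon, two bonds along the chain from an aromatic carbon. The step that bears on this is the one with hydroxy in place of propyl, from compound 1 to compound 3, which went beyond the scatter, while a number 5.2 percentage points higher from compound 2 to compound 3 (within the scatter) stayed within it. A modest upward step is therefore expected for compound 4, a number 11.5 percentage points higher from compound 1 to compound 4 (beyond the scatter). Compound 4 is estimated at 8%, in the range -8% to 24%.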

Compound 4, a percentage reported as inhibition, at one concentration (the size of the read-out at that concentration, not a potency): 4.54%
Estimate against measurement, compound 4: 3.5 percentage points above; low and high end bracket the measured number.
By their numbers in this assay, from the lowest: compounds 1, 4, 2 and 3 (each within the scatter of the next, the first and the last beyond it).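

In this assay, the 2-hydroxyethyl group of compound 4 does not repeat the result seen with hydroxymethyl, as its step from butyl stays within the scatter (a number 8 percentage points higher from compound 1 to compound 4 (within the scatter)). Compound 4 also cannot be told apart from the hydroxymethyl compound (a number 7 percentage points lower from compound 3 to compound 4 (within the scatter)) or from the 4-bromophenyl compound (a number 1.7 percentage points lower from compound 2 to compound 4 (within the scatter)), so among these steps at this position, only the one from compound 1 to compound 3 goes beyond the scatter. Nothing available accounts for these differences.

From the compounds shown here alone, it remains open whether an amine, a carboxylic acid or a longer hydroxyalkyl chain here would give a step beyond the scatter.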